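A few compounds are considered here, and "the series" means these few. Any claim that something is new, unique, unknown or untested is made for them only; others in the source may bear on it.

Measured compounds:
compound 1, `Cc1ccc(N2CCN(C(=O)[C@H]3[C@@H](c4ccc(Cl)cc4)CCN3C(C)C)CC2)c([C@@H](N)C(C)C)c1`, 110 nM
compound 2, `CC(C)C[C@H](N)c1cc(C(F)(F)F)ccc1N1CCN(C(=O)C2NCCC2c2ccc(Cl)cc2)CC1`, 98 nM

In an assay on HEK293 cells for displacement of a labelled ligand from Melanocortin receptor 4 (Homo sapiens) (a lower number here means a stronger inhibitor, a higher number a weaker inhibitor), compound 1 gives 110 nM, and compound 2 gives 98 nM; the two numbers lie within the usual scatter of each other, so the data show no separation between them in this assay. For the measured compounds named here, no step between the two has been worked out, since they differ in more than one place.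

Compound 3, `Cc1ccc(N2CCN(C(=O)[C@H]3[C@@H](c4ccc(Cl)cc4)CCN3C(=O)C(C)(C)C)CC2)c([C@@H](N)C(C)C)c1`, has not yet been measured. It differs from compound 1 by a single change: (tert-butyl)carbonyl in place of isopropyl on an amine nitrogen in a ring. Going by the values given here, with no measured pair that isolates this change, the expectation for compound 3 rests on the structural change alone. It is estimated that the step from compound 1 to compound 3 goes toward a weaker inhibitor, a 3.6-fold higher number from compound 1 to compound 3 (0.56 log units; beyond the scatter), somewhat beyond the scatter. Compound 3 is therefore expected to give about 400 nM in this assay, with a range from 100 nM to 2000 nM.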

Compound 3, inhibition constant: 7.2 nM
Compound 3: middle estimate off by 56-fold (1.74 log units), on the high side; measured number below the stated range.
By their numbers in this assay, from the lowest: compound 3; then compounds 2 and 1 (each within the scatter of the next).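

In this assay, for the compounds shown here, placing (tert-butyl)carbonyl instead of isopropyl on the amine nitrogen in the five-membered ring gives a 15-fold lower number from compound 1 to compound 3 (1.18 log units; beyond the scatter) and so separates compounds for the first time. The earlier values gave no view of this position on its own, whereas this pair shows that the group on this nitrogen can strongly change the number, and that the larger group bearing a carbonyl goes with the lower one. Nothing available explains the size of this step.

The pair does not separate the carbonyl from the tert-butyl part, a question that an acetyl group or a neopentyl group on this nitrogen would address. Also open, from the compounds shown here alone, is how this change behaves on the core of compound 2, which carries trifluoromethyl and a longer amine-bearing chain and has an unsubstituted ring nitrogen.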